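A few compounds are considered here, and "the series" means these few. Any claim that something is new, unique, unknown or untested is made for them only; others in the source may bear on it.

Among the compounds with values here, compound 1 `CCOC(=O)c1c(C)nc(-c2cccc(C#N)c2)n1OCCCO` gives 11400 nM in a functional assay on a cell-free system (plasma, Oryctolagus cuniculus) for inhibition, with stated times of 5 min, 1 min and 6 min (on this read-out lower numbers stand for stronger inhibition and higher numbers for weaker inhibition), the highest of the two numbers known so far. Compound 2 `CCOC(=O)c1c(C)nc(-c2cccc(C#N)c2)n1OCc1ccccc1F` gives 8990 nM in this assay; the step of a 1.3-fold lower number from compound 1 to compound 2 (0.10 log units; within the scatter) leaves the two within the scatter of each other, so no order between them can be read from these numbers. Compound 3 `CCOC(=O)c1c(C)nc(-c2cccc(C#N)c2)n1OCc1ccc(C#N)cc1` is not yet measured. It differs from compound 1 in one place: 4-cyanophenyl in place of 2-hydroxyethyl on a saturated chain carbon bound to an oxygen on an aromatic ring. Within the data shown here, the only measured step that bears on this change is a 1.3-fold lower number from compound 1 to compound 2 (0.10 log units; within the scatter), in which 2-fluorophenyl took the place of the same 2-hydroxyethyl at the same place on the shared core, and that step did not move the number beyond the scatter. The change to compound 3 is of the same kind, an aromatic group in place of the 2-hydroxyethyl, so a step of similar size is expected, a 1.4-fold lower number from compound 1 to compound 3 (0.15 log units; within the scatter), and nothing in the measured pair supports a move beyond the scatter. The estimate for compound 3 in this assay is 8000 nM, with a range from 3500 nM to 18000 nM.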

Compound 3, half-maximal inhibitory concentration: 4240 nM
Estimate against measurement, compound 3: 1.9-fold (0.28 log units) above; measured number inside the range.
By their numbers in this assay, from the lowest: compound 3; then compounds 2 and 1 (each within the scatter of the next).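

At this position, on a saturated chain carbon bound to an oxygen on an aromatic ring, the substituent can move the number in this assay: replacing 2-hydroxyethyl with 4-cyanophenyl gives a 2.7-fold lower number from compound 1 to compound 3 (0.43 log units; beyond the scatter) and so goes beyond the scatter, which the earlier change to 2-fluorophenyl did not do. The identity of the aromatic group also counts, not only the presence of an aromatic ring, as 4-cyanophenyl in place of 2-fluorophenyl gives a 2.1-fold lower number from compound 2 to compound 3 (0.33 log units; beyond the scatter), although both steps remain modest. No measurement at hand accounts for either step.

The compounds shown cannot separate a contribution of the nitrile from that of the aromatic ring carrying it, and a plain phenyl group at this position would be the direct test, with a carboxylic acid or an amine in place of the nitrile showing whether other groups on that ring give a similar number. On these data alone, it also remains open whether a longer chain between the oxygen and the 4-cyanophenyl group would keep this modest step in the same assay, this assay.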